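Amide-side extension in a pyridine series: expectation before measurement

A few compounds are considered here, and "the series" means these few. Any claim that something is new, unique, unknown or untested is made for them only; others in the source may bear on it.

compound 1 `CNC(=O)/C=C/c1ccncc1-c1ccc2ccccc2c1` gives 101%
compound 2 `CN1CCN(C(=O)/C=C/c2ccncc2-c2ccc(F)cc2)CC1` gives 84%
compound 3 `CNC(=O)CCc1ccncc1-c1ccc2ccccc2c1` gives 100%

In an assay on a protein complex for inhibition of CDK8/Cyclin C (Homo sapiens), with a stated time of 1 h, tested at 10 uM (on this read-out higher numbers stand for more inhibition at the one concentration tested (going by the name of the read-out) and lower numbers for less inhibition), compound 1 stands highest of the three numbers; compound 3 lies within the scatter of it, while compound 2 lies a larger distance below it. Within the data shown here, the only single-point step, a number 1 percentage points lower from compound 1 to compound 3 (within the scatter), concerns the chain between the core and the amide and is within the scatter. Compound 4 `O=C(O)CCNC(=O)/C=C/c1ccncc1-c1ccc2ccccc2c1` differs from compound 1 by carboxymethyl in place of hydrogen on a saturated chain carbon bound to an amide-type nitrogen. Among the measured compounds shown here, no measured step touches the group on the amide nitrogen, so nothing bears directly on this change; compound 2 differs from compound 1 in two places at once and gives no single-point reading. For compound 4 the expected step is a number 9 percentage points lower from compound 1 to compound 4 (within the scatter), a small fall at most. Compound 4 is estimated at 92%, within 70% to 103%.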

Compound 4, a percentage reported as inhibition, at one concentration (the size of the read-out at that concentration, not a potency): 91%
For compound 4 the middle estimate is 1 percentage points above the measured one; low and high end bracket the measured number.
By their numbers in this assay, from the lowest: compounds 2, 4, 3 and 1 (each within the scatter of the next, the first and the last beyond it).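

In this assay, among these compounds, the methylcarbamoyl group gives way to (2-carboxyethyl)carbamoyl with a number 10 percentage points lower from compound 1 to compound 4 (within the scatter) and this is the first single-place reading on the group on the amide nitrogen. The position carries the added carboxymethyl, with its carboxylic acid, without a step beyond the scatter. Nothing measured here accounts for this result.

Still open, going by these compounds, is whether a 2-aminoethyl group, or a longer chain ending in a carboxylic acid, reads the same on the amide nitrogen. Also open, on these data alone, is whether 2-carboxyethyl reads the same on the saturated chain of compound 3.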